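Anilino in Place of tert-Butyl on the Carbonyl Carbon

This account rests on a few compounds, and the source may have more. Where it says the series, first, only, none or still open, it means among the compounds named here.

The measured compounds and their values in a functional assay on HCT-116 cells (Homo sapiens) for antiproliferative activity, read by MTT assay, with a stated time of 72 h; on this read-out higher numbers stand for weaker inhibition and lower numbers for stronger inhibition:

compound 1, `CN(C(=O)C(C)(C)C)c1ccc2[nH]c(-c3n[nH]c4ccccc34)cc2n1`, gives 18000 nM
compound 2, `CN(C(=O)CCc1ccccc1)c1ccc2[nH]c(-c3n[nH]c4ccccc34)cc2n1`, gives 11200 nM
compound 3, `COc1ccc(S(=O)(=O)N(C)c2ccc3[nH]c(-c4n[nH]c5ccccc45)cc3n2)cc1OC`, gives 16700 nM

Compound 1 stands at the highest of the three numbers, but its nearest neighbour, compound 3, sits within the scatter of it, and compound 2 is likewise within the scatter. Nothing among the three is separated from the rest by more than the usual spread of repeated measurements, so no order among them can be claimed.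

Compound 4, `CN(C(=O)Nc1ccccc1)c1ccc2[nH]c(-c3n[nH]c4ccccc34)cc2n1`, has not yet been measured. It differs from compound 1 in one place: anilino in place of tert-butyl on a carbonyl carbon. Going by the values given here, the only measured step that touches the same carbonyl carbon is a 1.6-fold lower number from compound 1 to compound 2 (0.21 log units; within the scatter), a change of group on that carbon that left the number where it was. Compound 3, which carries a different linking group at the same nitrogen, shows a value close to compound 1 as well. On this evidence the shared core seems to set the level and the group on the carbonyl carbon to matter little, so the expectation for compound 4 is a step of a 1.3-fold lower number from compound 1 to compound 4 (0.11 log units; within the scatter), within the scatter. The estimate for compound 4 is 14000 nM, with a range from 5000 nM to 35000 nM.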

Compound 4, half-maximal inhibitory concentration: 1.3 nM
Estimate against measurement, compound 4: 11000-fold (4.03 log units) above; measured number below the stated range.
By their numbers in this assay, from the lowest: compound 4; then compounds 2, 3 and 1 (each within the scatter of the next).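

In this assay, going by these compounds alone, the group on the carbonyl carbon turns out to be able to set the level, which the earlier compounds gave no sign of: anilino in place of tert-butyl gives a 14000-fold lower number from compound 1 to compound 4 (4.14 log units; beyond the scatter), and anilino in place of phenethyl gives an 8600-fold lower number from compound 2 to compound 4 (3.94 log units; beyond the scatter), where the exchange of tert-butyl for phenethyl had given only a 1.6-fold lower number from compound 1 to compound 2 (0.21 log units; within the scatter). The shared core therefore does not fix the level by itself, and compound 2 shows that a six-membered aromatic ring carried on a chain at this carbon does not go with a low number, while the same kind of ring in the anilino group of compound 4 does. What lies behind a step of this size remains unexplained, as no supporting measurement bears on it.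

The compounds shown leave open which part of the anilino group carries the step, the nitrogen with its hydrogen or the ring joined directly to it, a question that N-methylanilino, benzylamino or cyclohexylamino on the same carbon would address. They also leave open how far the phenyl ring tolerates added groups, such as a fluorine, a methoxy group or a carboxylic acid.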